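The source may hold more compounds than are shown below. What is called first, only, known or untested is meant among the compounds shown, and "the series" means these compounds.

Measured compounds in a functional assay on EBC-1 cells (Homo sapiens) for inhibition, read by sulforhodamine B assay, with a stated time of 72 h; on this read-out lower numbers stand for stronger inhibition and higher numbers for weaker inhibition:
Compound 1, `COCCOc1ccc2c(OCCn3c(=O)oc4cc(C)ccc43)ccnc2c1`, gives > 500 nM, which is a limit of the measurement rather than a number.
Compound 2, `Cc1ccc2c(c1)oc(=O)n2CCOc1ccnc2cc(-c3cnn(C)c3)ccc12`, gives 35 nM.
Compound 3, `COc1ccc2c(OCCn3c(=O)oc4ccc(C)cc43)ccnc2c1`, gives > 500 nM, again a limit rather than a number.

Compound 3 thus stands at the limit, and the limit of > 500 nM in this assay, at which 2 of the 3 values shown sit, shows that this is where most of the values seen so far sit. Compound 4, `COc1ccc2c(OCCn3c(=O)oc4ccc(-c5cnn(C)c5)cc43)ccnc2c1`, differs from compound 3 in one place: 1-methyl-1H-pyrazol-4-yl in place of methyl on an aromatic carbon. For the measured compounds named here, one measured step bears on this kind of change: an at least 14-fold lower number from compound 1 to compound 2 (1.15 log units; beyond the scatter). Going by the values given here, there the same pyrazolyl group entered the shared structure, though in place of a different group and at a different place from the one described for compound 4, so the comparison is only partial. A step of an at least 2.5-fold lower number from compound 3 to compound 4 (0.39 log units; beyond the scatter) is therefore expected, downward and beyond the scatter, but with wide uncertainty. Compound 4 is estimated at 200 nM, between 50 nM and 800 nM.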

Compound 4, half-maximal inhibitory concentration: > 500 nM
Compound 4: only a limit was reported; the forecaster's own chance of this, stated with the estimate: 40%; middle value at least 2.5-fold (0.39 log units) from the limit.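

Compound 3 and compound 4 both give a limit rather than a number in this assay, so no step can be read between them: the limit of > 500 nM in this assay, at which 3 of the 4 values shown sit.

The compounds shown leave open whether 1-methyl-1H-pyrazol-4-yl in place of methyl at this place changes inhibition at all.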